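This account rests on a few compounds, and the source may have more. Where it says the series, first, only, none or still open, it means among the compounds named here.

In a functional assay for agonist activity at G protein-coupled receptor 88 (Homo sapiens), read by HTRF and cAMP accumulation (on this read-out higher numbers stand for an effect only at larger amounts of compound and lower numbers for an effect already at smaller amounts), compound 1 `CC(C)C[C@H](N)CN(C(=O)[C@@H]1C[C@H]1c1ccccc1)c1ccc(-c2ccccc2)cc1` gives 880 nM, compound 2 `CC[C@H](C)[C@H](N)CN(C(=O)[C@@H]1C[C@H]1c1cccc(F)c1)c1ccc(-c2ccccc2)cc1` gives 560 nM, and compound 3 `CC[C@H](C)[C@H](N)CN(C(=O)[C@@H]1C[C@H]1c1cccc(C#N)c1)c1ccc(-c2ccccc2)cc1` gives 1600 nM. Compound 3 thus carries the highest of the three numbers in this assay; its nearest neighbour is compound 1, a gap within the scatter, and its furthest is compound 2, a gap beyond the scatter. Among the compounds with values here, the one single-point change measured so far is a 2.9-fold higher number from compound 2 to compound 3 (0.46 log units; beyond the scatter), cyano in place of fluoro on an aromatic carbon. Compound 4 `CC[C@H](C)[C@H](N)CN(C(=O)[C@@H]1C[C@H]1c1cncnc1)c1ccc(-c2ccccc2)cc1` differs from compound 3 in one place: pyrimidin-5-yl in place of 3-cyanophenyl on a saturated ring carbon Read one bond further out, the change runs from 2-(3-cyanophenyl)cyclopropyl to 2-(pyrimidin-5-yl)cyclopropyl. Within the data shown here, no measured step covers this exchange of the aromatic ring itself; the only measured step in this assay concerned a substituent on that ring and was a modest rise. With no direct anchor, compound 4 is expected to land near compound 3, leaning toward a modest rise. For compound 4 the expected step is a 1.6-fold higher number from compound 3 to compound 4 (0.19 log units; within the scatter). Compound 4 is therefore estimated at 2500 nM, within a range of 800 nM to 8000 nM.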

Compound 4, half-maximal effective concentration: 19000 nM
For compound 4 the middle estimate is 7.6-fold (0.88 log units) below the measured one; measured number above the stated range.
By their numbers in this assay, from the lowest: compounds 2, 1 and 3 (each within the scatter of the next, the first and the last beyond it); then compound 4.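

In this assay, replacing the aromatic ring itself on this saturated ring carbon proves a far larger change than swapping a substituent on that ring: the exchange gives a 12-fold higher number from compound 3 to compound 4 (1.07 log units; beyond the scatter) and a 34-fold higher number from compound 2 to compound 4 (1.53 log units; beyond the scatter), both large, against the modest 2.9-fold higher number from compound 2 to compound 3 (0.46 log units; beyond the scatter). The position therefore responds strongly to the identity of the ring it carries, and pyrimidin-5-yl costs far more here than either substituted phenyl group shown. Nothing available accounts for the size of this loss.

The compounds shown do not separate the two things that change together in this exchange: the ring nitrogens and the loss of the substituent on the ring. A pyridin-3-yl group at this position, or a pyrimidin-5-yl ring carrying a nitrile, would be needed to tell these apart.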